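The source may report more compounds than this note shows. Statements on the series, on what has been measured and on what is new or still open speak of the compounds shown alone.

Of the compounds shown here, three built on a shared core have been tested in a functional assay on MDA-MB-468 cells (Homo sapiens) for inhibition, read by sulforhodamine B assay, with a stated time of 48 h; a lower number here means that less compound is tolerated, a higher number that more compound is tolerated. Compound 1 `COc1ccc(-c2cc(/C=C/C(=O)c3ccc(N)cc3)[nH]n2)cc1` gives 7450 nM in this assay. Compound 2 `COc1ccc(-c2cc(/C=C/C(=O)c3ccc(N)cc3)[nH]n2)cc1OC` gives 7800 nM in this assay. Compound 2 and compound 1 differ in one place: hydrogen in place of methoxy on an aromatic carbon. That change made a 1.0-fold lower number from compound 2 to compound 1 (0.02 log units; within the scatter). Compound 3 `COc1cc(C(=O)/C=C/c2cc(-c3cc(OC)c(OC)c(OC)c3)n[nH]2)cc(OC)c1OC` gives 5370 nM in this assay; how the core of compound 3 differs from that of compound 2 is not broken down here. All three values lie within the usual scatter of one another, so no order among them can be drawn from these numbers.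

Compound 4 `COc1ccc(-c2cc(/C=C/C(=O)c3cc(OC)c(OC)c(OC)c3)[nH]n2)cc1OC` has not yet been measured in this assay. It differs from compound 3 in one place: hydrogen in place of methoxy on an aromatic carbon. Among the compounds with values here, this is the same kind of change as the one from compound 2 to compound 1, though the surroundings are not identical: in compound 3 the aromatic carbon that loses the methoxy is also meta to a methoxy group, which is not the case in compound 2. Resting on a 1.0-fold lower number from compound 2 to compound 1 (0.02 log units; within the scatter), compound 4 is expected to make a step of a 1.1-fold higher number from compound 3 to compound 4 (0.05 log units; within the scatter) in this assay, since that earlier change left the number essentially unchanged. The estimate for compound 4 in this assay is 6000 nM, with an expected range from 3000 nM to 12000 nM.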

Compound 4, concentration lethal to 50% of the cells: 8030 nM
For compound 4 the middle estimate is 1.3-fold (0.13 log units) below the measured one; the range from low to high includes it.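

In this assay, putting hydrogen in place of methoxy on an aromatic carbon gave a 1.5-fold higher number from compound 3 to compound 4 (0.17 log units; within the scatter), so on this core, as on the earlier one, the step stays within the usual scatter of repeated measurements. Setting the two steps side by side shows that they cannot be told apart, which means the earlier result carried over to this second core as far as this assay can tell: the same change on two cores in this assay, a 1.0-fold lower number (0.02 log units; within the scatter) from compound 2 to compound 1 and a 1.5-fold higher number (0.17 log units; within the scatter) from compound 3 to compound 4, 1.6-fold (0.19 log units) apart, within the scatter of two such steps. This does not show that the change has no effect at all, since a small real step could be hidden within the scatter, and two cores are too few to support a rule for other cores in the series.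

The compounds shown leave open whether anything other than hydrogen or methoxy at this place, such as an amine, a carboxylic acid or a longer chain like butoxy, would give a step beyond the scatter. They also leave open whether losing a methoxy group from another place on these rings would stay within the scatter as these two steps did.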